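Three Level Readings and One Untested Group Exchange

The source may hold more compounds than are shown below. What is called first, only, known or untested is meant among the compounds shown, and "the series" means these compounds.

In an ADME assay on HEK293 cells (Homo sapiens) for cytotoxicity, read by MTT assay, with a stated time of 24 h (a lower number here means a stronger inhibitor, a higher number a weaker inhibitor), compound 1 (`CN(C)CCCCNc1nc2cc([N+](=O)[O-])ccc2nc1NCc1ccc(C(F)(F)F)cc1`) gives 9.73 ug/mL, compound 2 (`O=[N+]([O-])c1ccc2nc(NCc3ccc(C(F)(F)F)cc3)c(N3CCNCC3)nc2c1`) gives 9.61 ug/mL and compound 3 (`CN(C)CCCNc1nc2cc([N+](=O)[O-])ccc2nc1NCc1ccc(Br)cc1`) gives 9.63 ug/mL. Compound 3 therefore stands level with the other two, within the scatter of both. Compound 4 (`CN(C)CCCNc1nc2cc([N+](=O)[O-])ccc2nc1NCc1ccccc1C(F)(F)F`) carries 2-(trifluoromethyl)phenyl in place of 4-bromophenyl on a saturated chain carbon bound to a nitrogen on an aromatic ring. Going by the values given here, only one measured step changes a single place, a 1.0-fold lower number from compound 1 to compound 2 (0.01 log units; within the scatter), and it lies within the scatter. That step concerns a different group, so it bears on this exchange only indirectly. Among the compounds with values here, no measured compound carries 2-(trifluoromethyl)phenyl, which leaves the exchange itself untested. Given the flat readings so far, no step beyond the scatter is expected in this assay, though a wide margin is warranted. The expected step is a 1.0-fold lower number from compound 3 to compound 4 (0.00 log units; within the scatter). For compound 4, the estimated value is 9.6 ug/mL, with an expected range of 6 ug/mL to 15 ug/mL.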

Compound 4, half-maximal inhibitory concentration: 24.7 ug/mL
Estimate against measurement, compound 4: 2.6-fold (0.41 log units) below; measured number outside the range, above it.
By their numbers in this assay, from the lowest: compounds 2, 3 and 1 (each within the scatter of the next); then compound 4.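

In this assay, the exchange on a saturated chain carbon bound to a nitrogen on an aromatic ring gives a 2.6-fold higher number from compound 3 to compound 4 (0.41 log units; beyond the scatter), the first step shown that lies beyond the scatter. The level readings of compounds 1, 2 and 3 therefore did not extend to this change: this place can move the number, and here it moves towards a weaker inhibitor, even though the entering 2-(trifluoromethyl)phenyl and the leaving 4-bromophenyl both hold one six-membered aromatic ring of carbon only. Nothing available explains the step.

The compounds shown do not separate the change of substituent from the change in its ring position, since 4-bromophenyl and 2-(trifluoromethyl)phenyl differ in both. As far as these compounds go, it also remains open how an unsubstituted phenyl or a cyanophenyl would read at this same place.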